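Cytotoxicity on HeLa cells: a ring swap at the imidazolone nitrogen

This account rests on a few compounds, and the source may have more. Where it says the series, first, only, none or still open, it means among the compounds named here.

Measured compounds:
compound 1 `N=C(CCCn1c(Cn2c(=O)n(C3CC3)c3ccncc32)cc2cc(Cl)ccc21)NO`: > 50000 nM
compound 2 `O=c1n(Cc2cc3cnccc3n2CCCCO)c2cnccc2n1C1CC1`: > 100000 nM
compound 3 `N#CCCCn1c(Cn2c(=O)n(-c3ccc(C(=O)NC4CC4)cc3)c3ccncc32)cc2cc(Cl)ccc21`: > 50000 nM

In an ADME assay on HeLa cells (Homo sapiens) for cytotoxicity, read by ATP content, with a stated time of 3 days (on this read-out lower numbers stand for higher toxicity in this test and higher numbers for lower toxicity in this test), none of the three compounds produced a numerical value. Compound 1 reaches only a limit, > 50000 nM. Compound 2 likewise reaches only a limit, > 100000 nM. Compound 3 stands at a limit as well, > 50000 nM; this is where two of the three results sit, as the limit of > 50000 nM in this assay, at which 2 of the 3 values shown sit, shows, while the remaining result sits at the limit of > 100000 nM in this assay, at which 1 of the 3 values shown sits. On this read-out, then, compound 3 cannot be ordered against the other two; all that is known is that none showed toxicity within the tested range.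

Compound 4 `N#CCCCn1c(Cn2c(=O)n(-c3ccncc3F)c3ccncc32)cc2cc(Cl)ccc21` differs from compound 3 in one place: 3-fluoropyridin-4-yl in place of 4-(cyclopropylcarbamoyl)phenyl on an aromatic nitrogen. Within the data shown here, no measured step separates compounds that differ in one place, so the size of this change in this assay is unknown. Given that compound 3 already rests at a limit, the step that the limit leaves unreadable from compound 3 to compound 4 is expected to stay within the scatter, and compound 4 is expected to give 60000 nM, with a range from 15000 nM to 200000 nM.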

Compound 4, half-maximal cytotoxic concentration: > 50000 nM
Compound 4: no number, only a limit; the forecaster's own chance of this, stated with the estimate: 75%; the middle value is on the limit's open side.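

Among these compounds, compound 3 and compound 4 both rest at a limit in this assay, so no step between them can be read: the limit of > 50000 nM in this assay, at which 3 of the 4 values shown sit.

The compounds shown leave open where the half-maximal cytotoxic concentrations of compound 3 and compound 4 actually lie, and whether this exchange of groups changes the read-out at all.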